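Nitro on the phenyl of a chloroquinoline-linked pyrimidine series

This account rests on a few compounds, and the source may have more. Where it says the series, first, only, none or still open, it means among the compounds named here.

Measured so far in an ADME assay on HeLa cells (Homo sapiens) for cytotoxicity, read by microscopy; on this read-out higher numbers stand for lower toxicity in this test and lower numbers for higher toxicity in this test:
compound 1 `CSc1nc(NCCCNc2ccnc3cc(Cl)ccc23)c(C#N)c(-c2ccccc2)n1`, compound 1 gives 100000 nM
compound 2 `CSc1nc(NCCCCNc2ccnc3cc(Cl)ccc23)c(C#N)c(-c2ccccc2)n1`, compound 2 gives 100000 nM
compound 3 `CSc1nc(OCCCNc2ccnc3cc(Cl)ccc23)c(C#N)c(-c2ccccc2)n1`, compound 3 gives 4000 nM

Compound 2 stands level with compound 1 at the digits shown; together they carry the highest of the three numbers, and the gap between them lies within the scatter. Among the compounds with values here, the one value that is clearly apart is that of compound 3, which is lower than that of compound 2 by a margin beyond the scatter. Within the data shown here, no pair here differs in only one place, so no single step between measured compounds can be put into numbers; the two values of compound 2 and compound 3 simply show that an oxygen link in place of the amine link goes with the lower number.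

Compound 4 `CSc1nc(NCCCCNc2ccnc3cc(Cl)ccc23)c(C#N)c(-c2cccc([N+](=O)[O-])c2)n1` is the next compound to be put into this assay. It differs from compound 2 as follows: nitro in place of hydrogen on an aromatic carbon. Nothing in the measured set carries a nitro group, so there is no shown step to rest on. The expectation is that the change from compound 2 to compound 4 gives a modest move downward, a 2.0-fold lower number from compound 2 to compound 4 (0.30 log units; within the scatter), if any move beyond the scatter at all. For compound 4 the expected value is 50000 nM, with a range from 10000 nM to 100000 nM.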

Compound 4, minimum cytotoxic concentration: 100000 nM
The estimate for compound 4 lay 2.0-fold (0.30 log units) below the measured number, and the stated range covers the measured number.
By their numbers in this assay, from the lowest: compound 3; then compounds 1, 2 and 4 (each within the scatter of the next).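

In this assay, the series now has its first readable step at the phenyl: nitro in place of hydrogen on an aromatic carbon, meta to a large group, gives no change at the digits printed from compound 2 to compound 4 (within the scatter). Within the data shown here, the earlier compounds held no pair differing in one place, so this is the first change whose size can be stated, and on the amine-linked background of compound 2, phenyl to 3-nitrophenyl leaves the read-out where it stood. No supporting measurement accounts for this result, so the flat step stands as an observation without an explanation.

Still open, going by these compounds, is whether the same nitro step stays flat on a compound with a lower number, such as the oxygen-linked compound 3 at 4000 nM, since this single pair comes from one background only. Also open, on these data alone, is how this same place on the phenyl responds to other groups, such as an amine, a carboxylic acid or a methoxy group, and whether a nitro group elsewhere on that ring reads the same.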